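Benzylamine series: one methoxy group removed

A few compounds are considered here, and "the series" means these few. Any claim that something is new, unique, unknown or untested is made for them only; others in the source may bear on it.

Compounds 1 to 4 share one core and differ in the side group. Compound 1 `Nc1cc(N)c2nc(-c3ccccc3)c(Oc3ccc(Cl)c(Cl)c3)nc2c1` carries an ether link and in a functional assay on SR cells (Homo sapiens) for inhibition, read by sulforhodamine B assay, with a stated time of 48 h (on this read-out higher numbers stand for weaker inhibition of growth and lower numbers for stronger inhibition of growth), compound 1 gives 24000 nM. Compound 2 `Nc1cc(N)c2nc(-c3ccccc3)c(NCc3ccc(Cl)c(Cl)c3)nc2c1` carries a benzylamine link and in this assay compound 2 gives 6030 nM. Compound 3 `COc1cc(CNc2nc3cc(N)cc(N)c3nc2-c2ccccc2)cc(OC)c1OC` carries a trimethoxybenzyl amine. In this assay compound 3 stands only at a limit, < 50200 nM, and not at a number; this is the limit described by the limit of < 50200 nM in this assay, at which 1 of the 3 values shown sits. Compound 4 `COc1ccc(CNc2nc3cc(N)cc(N)c3nc2-c2ccccc2)cc1OC` is the next member: hydrogen in place of methoxy on an aromatic carbon. Going by the values given here, no measured pair differing in one place exists in this set, so the size of this step is open; the difference is small, a methoxy group only, and a step within the usual scatter is the expectation, with no direction favoured. On that basis the step from compound 3 to compound 4 is expected to be a step that the limit leaves unreadable from compound 3 to compound 4. In this assay compound 4 is estimated at 12000 nM, with a range from 3000 nM to 45000 nM.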

Compound 4, concentration for total growth inhibition: 18200 nM
For compound 4 the middle estimate is 1.5-fold (0.18 log units) below the measured one; the measured number falls inside the stated range.
By their numbers in this assay, from the lowest: compound 2; then compounds 4 and 1 (each within the scatter of the next).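

The methoxy step itself cannot be read, because compound 3 stands only at a limit: the limit of < 50200 nM in this assay, at which 1 of the 4 values shown sits.

What compound 4 adds is a number for a methoxy-bearing benzylamine, which allows a one-place comparison on the benzylamine link. In this assay, 3,4-dimethoxyphenyl in place of 3,4-dichlorophenyl gives a 3.0-fold higher number from compound 2 to compound 4 (0.48 log units; beyond the scatter), so on this link the change of aryl group registers beyond the scatter, with the lower number on the dichlorinated compound.

From the compounds shown here alone, the effect of hydrogen in place of methoxy on this aromatic carbon remains open in both size and direction. Also open, going by these compounds, is how an amine or a carboxylic acid in place of this methoxy group, or a longer chain between the nitrogen and the aromatic ring, would read in this assay.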